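Pyridin-2-yl in place of pyridin-3-yl: what compound 4 may give

The source may hold more compounds than are shown below. What is called first, only, known or untested is meant among the compounds shown, and "the series" means these compounds.

Three compounds share a core: compound 1 `c1ccc(-n2nncc2-c2cccnc2)cc1`, compound 2 `FC(F)(F)c1ccc(-n2nncc2-c2cccnc2)cc1` and compound 3 `Brc1ccc(-n2nncc2-c2cccnc2)cc1`. In a functional assay on the whole organism with Mus musculus as the target, in the maximal electroshock model (a higher number here means that more compound is needed for the effect, a lower number that less compound is needed), compound 1 gives 76.4 mg/kg, compound 2 gives 92.3 mg/kg and compound 3 gives 87.2 mg/kg. Compound 3 therefore stands second highest of the three numbers, with compound 2 its nearest neighbour and compound 1 its furthest, both gaps within the scatter. The measured steps of a 1.2-fold higher number from compound 1 to compound 2 (0.08 log units; within the scatter), a 1.1-fold higher number from compound 1 to compound 3 (0.06 log units; within the scatter) and a 1.1-fold lower number from compound 2 to compound 3 (0.02 log units; within the scatter) all lie within the scatter, so the changes on the aromatic carbon of that ring left this assay unmoved.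

Compound 4 `Brc1ccc(-n2nncc2-c2ccccn2)cc1` differs from compound 3 by pyridin-2-yl in place of pyridin-3-yl on an aromatic carbon. Going by the values given here, none of the measured steps bears on this change, since each of them alters a different ring. With no evidence of movement anywhere in this small set, the step of a 1.0-fold lower number from compound 3 to compound 4 (0.00 log units; within the scatter) is expected to be none beyond the scatter. Compound 4 is accordingly estimated to give 87 mg/kg, within a range of 40 mg/kg to 190 mg/kg.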

Compound 4, dose for half-maximal effect: 68 mg/kg
Beside the measured number, compound 4's estimate is 1.3-fold (0.11 log units) above it, and the stated range covers the measured number.
By their numbers in this assay, from the lowest: compounds 4, 1, 3 and 2 (each within the scatter of the next).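

In this assay, pyridin-2-yl in place of pyridin-3-yl gives a 1.3-fold lower number from compound 3 to compound 4 (0.11 log units; within the scatter). Going by these compounds alone, the earlier steps changed only the group on the other ring, so this is the first sign that the place on the five-membered aromatic ring with 3 nitrogen, too, shows no movement beyond the scatter when the ring nitrogen of the pyridine group shifts. Nothing available explains the result or shows how either group acts at this place.

Going by these compounds, whether pyridin-4-yl or a plain phenyl at this place, or an amine or a carboxylic acid on that ring, would move the number beyond the scatter remains open. So does whether pyridin-2-yl would give a similar result with hydrogen or trifluoromethyl in place of bromo.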